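Replacing an aryl ether on the core: expected efficacy

The source may report more compounds than this note shows. Statements on the series, on what has been measured and on what is new or still open speak of the compounds shown alone.

Compound 1, `COc1ccc(Oc2ccc([C@H]3S[C@@H](C)C(=O)Nc4c3c(C)nn4-c3ccccc3C)cc2)cc1`: 70%
Compound 2, `Cc1nn(-c2ccccc2Br)c2c1C(c1ccc(Oc3ccccc3)cc1)SC(C)C(=O)N2`: 84%

Two compounds have numbers in an assay on isolated protein for agonist activity at Bile acid receptor (Homo sapiens), read by AlphaScreen, with a stated time of 30 min; on this read-out lower numbers stand for smaller maximal responses and higher numbers for larger maximal responses. Compound 1 gives 70% and is the lowest of the two; its nearest neighbour, compound 2, gives 84%, a number higher by more than the usual scatter. Going by the values given here, no step between measured compounds that differ in one place is recorded, so nothing measured separates the effect of any single change.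

The account now follows the step from compound 1 to compound 3, `Cc1ccccc1-n1nc(C)c2c1NC(=O)[C@H](C)S[C@@H]2c1ccc(-c2ccccc2)cc1`. Compound 3 differs from compound 1 in one place: phenyl in place of 4-methoxyphenoxy on an aromatic carbon. The phenyl enters on an aromatic carbon of a six-membered aromatic ring of carbon only, para to a large group.

Among the compounds with values here, with no measured step to lean on, the expectation for a number 8 percentage points higher from compound 1 to compound 3 (within the scatter) is a small rise, within or barely beyond the scatter. Compound 3 is thus estimated at 78%, with a range from 60% to 95%.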

Compound 3, largest response reached (reported as efficacy), in percent of the reference or control that the assay uses: 24%
Beside the measured number, compound 3's estimate is 54 percentage points above it; measured number below the stated range.
By their numbers in this assay, from the lowest: compound 3; then compound 1; then compound 2.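

In this assay, going by these compounds alone, phenyl in place of 4-methoxyphenoxy on an aromatic carbon gives a number 46 percentage points lower from compound 1 to compound 3 (beyond the scatter), the first single-place step here, so the maximal response depends strongly on what this position carries. The group that leaves holds oxygen and hydrogen-bond acceptors and the phenyl that enters holds neither, yet this one step cannot show which difference between the two groups matters. Nothing measured here explains the drop.

The compounds shown leave open whether the loss follows from removing the oxygen that links the outer ring or the methoxy group, or from shortening the substituent as a whole. They also leave open how a benzyloxy group, a pyridyl ring or a morpholine at this carbon would compare.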